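Replacing the hydroxycyclohexyl group of compound 1

The source may report more compounds than this note shows. Statements on the series, on what has been measured and on what is new or still open speak of the compounds shown alone.

Within the data shown here, in a functional assay on RS4-11 cells (Homo sapiens) for inhibition, read by CCK-8 assay, with a stated time of 48 h (on this read-out lower numbers stand for stronger inhibition and higher numbers for weaker inhibition), compound 1 `O=S(=O)(NCCNC(=S)Nc1cc(C(F)(F)F)cc(C(F)(F)F)c1)c1ccc(-c2ccccc2O[C@H]2CC[C@@H](O)CC2)s1` stands at 6300 nM and compound 2 `O=C(Nc1ccc(F)cc1)N1CCN(S(=O)(=O)c2sccc2-c2ccccc2Oc2ccc(O)c(O)c2)CC1` at 6800 nM within the scatter of each other, so neither holds a real lead on the numbers so far. Compound 3 `O=[N+]([O-])c1ccc(Oc2ccccc2-c2ccc(S(=O)(=O)NCCNC(=S)Nc3cc(C(F)(F)F)cc(C(F)(F)F)c3)s2)cc1` keeps the core of compound 1 and differs in one place, with 4-nitrophenyl in place of 4-hydroxycyclohexyl on an oxygen on an aromatic ring. Among the measured compounds shown here, no measured step bears on this change. In this assay no shift beyond the scatter is expected (a 1.3-fold lower number from compound 1 to compound 3 (0.10 log units; within the scatter)). Compound 3 is estimated at 5000 nM (range 1500 nM to 15000 nM).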

Compound 3, half-maximal inhibitory concentration: 6300 nM
Compound 3: middle estimate off by 1.3-fold (0.10 log units), on the low side, within the range that was stated.
By their numbers in this assay, from the lowest: compounds 1, 3 and 2 (each within the scatter of the next).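

In this assay the read is no change at the digits printed from compound 1 to compound 3 (within the scatter). On an oxygen on an aromatic ring, a six-membered non-aromatic ring of carbon only thus gives way to a six-membered aromatic ring, with no shift beyond the scatter and with both defined stereocentres gone. Nothing available explains why the number holds.

As far as these compounds go, whether any group on this oxygen moves the number beyond the scatter stays open. An amine or a carboxylic acid in place of the nitro group on the phenyl ring would test this.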